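Replacing a pyridinyl arm with 2-methoxyphenyl

This account rests on a few compounds, and the source may have more. Where it says the series, first, only, none or still open, it means among the compounds named here.

Compound 1, `CC(C)(C)c1cc2nn(-c3ccccc3)c(N)c2c(=O)[nH]1`, gives 5% in an assay on isolated protein for inhibition of serine/threonine-protein kinase Chk2 (Homo sapiens), read by mobility shift assay, tested at 30 uM; a lower number here means less inhibition, a higher number more inhibition at the concentration tested (going by the name of the read-out). Compound 2, `Nc1c2c(=O)[nH]c(-c3ccccn3)cc2nn1-c1ccccc1`, gives 3%.

Compound 2 stands lowest of the two numbers, but the step of a number 2 percentage points lower from compound 1 to compound 2 (within the scatter) shows that these two values are indistinguishable. Compound 3, `COc1ccccc1-c1cc2nn(-c3ccccc3)c(N)c2c(=O)[nH]1`, carries the change (2-methoxyphenyl in place of pyridin-2-yl on an aromatic carbon). Among the measured compounds shown here, the only measured step, the exchange of tert-butyl for pyridin-2-yl at the same place, left the read-out unchanged, so a further exchange there is expected to give no step beyond the scatter, a number 2 percentage points higher from compound 2 to compound 3 (within the scatter). Compound 3 is therefore estimated at 5%, within 0% to 20%.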

Compound 3, a percentage reported as inhibition, at one concentration (the size of the read-out at that concentration, not a potency): 16%
The estimate for compound 3 lay 11 percentage points below the measured number; measured number inside the range.
By their numbers in this assay, from the lowest: compounds 2 and 1 (each within the scatter of the next); then compound 3.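

At this position on the shared core, the read-out in this assay can move: 2-methoxyphenyl gives a number 13 percentage points higher from compound 2 to compound 3 (beyond the scatter) and a number 11 percentage points higher from compound 1 to compound 3 (beyond the scatter), whereas tert-butyl and pyridin-2-yl could not be told apart. Among the compounds shown here, the one earlier exchange therefore did not predict the result of the next. Nothing available explains the difference.

On these data alone, whether the methoxy group or the carbon-only ring carries the step remains open. A plain phenyl could separate the two, while an amine or a carboxylic acid would test other kinds of group here.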